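Chloro for methoxy, carried over to a second core

The source may report more compounds than this note shows. Statements on the series, on what has been measured and on what is new or still open speak of the compounds shown alone.

Compound 1 `COc1cc(N2CC(NC(=O)c3cc4c(C)n(C)nc4cn3)C2)c(Cl)cn1` and compound 3 `Cc1c2cc(C(=O)NC3CN(c4cc(Cl)ncc4Cl)C3)ncc2nn1C` share one core; compound 2 `COc1cc(N2CC(NC(=O)c3cn4c(C)c(C)nc4cn3)C2)c(Cl)cn1` and compound 4 `Cc1nc2cnc(C(=O)NC3CN(c4cc(Cl)ncc4Cl)C3)cn2c1C` share another, and the difference between the two cores is not broken down here. In an ADME assay on microsomes (Homo sapiens) for metabolic stability (a lower number here means slower removal, a higher number faster removal of the compound), compound 1 gives 28 mL/min/kg, compound 3 gives 26 mL/min/kg and compound 2 gives 25 mL/min/kg. The change from compound 1 to compound 3, (chloro in place of methoxy on an aromatic carbon), made a 1.1-fold lower number from compound 1 to compound 3 (0.03 log units; within the scatter). Compound 4 carries the same change on the core of compound 2, (chloro in place of methoxy on an aromatic carbon). Because the earlier change gave a 1.1-fold lower number from compound 1 to compound 3 (0.03 log units; within the scatter), the same change is expected to give a 1.0-fold lower number from compound 2 to compound 4 (0.02 log units; within the scatter). Compound 4 is therefore estimated at 24 mL/min/kg in this assay, with an expected range from 14 mL/min/kg to 40 mL/min/kg.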

Compound 4, clearance: 33 mL/min/kg
Compound 4: middle estimate off by 1.4-fold (0.14 log units), on the low side; measured number inside the range.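

On the core of compound 2, chloro in place of methoxy gave a 1.3-fold higher number from compound 2 to compound 4 (0.12 log units; within the scatter) in this assay. Set beside the earlier step, the change reads alike on both cores, with the two steps no further apart than the scatter allows: the same change on two cores in this assay, a 1.1-fold lower number (0.03 log units; within the scatter) from compound 1 to compound 3 and a 1.3-fold higher number (0.12 log units; within the scatter) from compound 2 to compound 4, 1.4-fold (0.15 log units) apart, within the scatter of two such steps. Among the compounds shown here, this shows that, on these two cores, going from 5-chloro-2-methoxypyridin-4-yl to 2,5-dichloropyridin-4-yl gives no step that can be told from the scatter, but it does not show a fixed effect of the change, and two pairs set no rule for other cores.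

The compounds shown leave open how other groups in this place, such as an amine, a nitrile or a longer alkoxy chain, would read in this assay. They also leave open whether any such group would separate the two cores.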